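The source may hold more compounds than are shown below. What is called first, only, known or untested is meant among the compounds shown, and "the series" means these compounds.

Working notes on the series, all read in a functional assay on K562 cells (Homo sapiens) for antiproliferative activity, read by CCK-8 assay, with a stated time of 72 h; on this read-out higher numbers stand for weaker inhibition of growth and lower numbers for stronger inhibition of growth. Compound 3 `CC[C@@H]1C(=O)N(C)c2cnc(-n3ccc4ccccc43)nc2N1C1CCCC1` gives 6910 nM. Among the measured compounds shown here, compound 2 `CCC1C(=O)N(C)c2cnc(-n3ccc4cc(C(=O)NC(C)C)ccc43)nc2N1c1ccn(C)n1` gives 8910 nM, within the scatter of compound 3, although it differs from compound 3 in more than one place and so offers no clean step. Compound 1 `CC[C@@H]1C(=O)N(C)c2cnc(-n3ccc4cc(C(N)=O)ccc43)nc2N1C1CCCC1` gives 1850 nM, which leaves compound 3 on the high-number side of this small set, clearly short of compound 1.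

The next structure is compound 4 `CC[C@@H]1C(=O)N(C)c2cnc(-n3ccc4cc(C(=O)NC)ccc43)nc2N1C1CCCC1`, which has methylcarbamoyl in place of hydrogen on an aromatic carbon. For the measured compounds named here, the one measured step bearing on this is a 3.7-fold higher number from compound 1 to compound 3 (0.57 log units; beyond the scatter), a modest step beyond the scatter, where hydrogen replaces carbamoyl on the same aromatic carbon. Read in reverse, it points towards a lower number for an amide at this carbon. Going by the values given here, no measured step isolates the methyl on the amide nitrogen, so the size carries over only loosely, and a somewhat smaller gain than that of compound 1 seems the cautious expectation. The expected change is a 2.5-fold lower number from compound 3 to compound 4 (0.39 log units; beyond the scatter), towards stronger inhibition of growth. For compound 4 the estimated value is 2800 nM, with an expected range from 1200 nM to 6000 nM.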

Compound 4, concentration for 50% growth inhibition: 705 nM
Estimate against measurement, compound 4: 4.0-fold (0.60 log units) above, outside the stated range (below it).
By their numbers in this assay, from the lowest: compound 4; then compound 1; then compounds 3 and 2 (each within the scatter of the next).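

At this aromatic carbon, methylcarbamoyl in place of hydrogen gives a 9.8-fold lower number from compound 3 to compound 4 (0.99 log units; beyond the scatter) in this assay, so the gain from an amide here can go well beyond what the primary amide alone showed in a 3.7-fold higher number from compound 1 to compound 3 (0.57 log units; beyond the scatter). Among the compounds shown here, the methyl on the amide nitrogen, which no earlier step isolated, has its own effect: methyl in place of hydrogen on that nitrogen gives a 2.6-fold lower number from compound 1 to compound 4 (0.42 log units; beyond the scatter), and this step lies beyond the scatter, so the amide nitrogen is a place where one small change still moves the number. Across the three compounds that share everything else, the number therefore falls from hydrogen in compound 3 through carbamoyl in compound 1 to methylcarbamoyl in compound 4, and none of the three goes against this order.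

Still open, as far as these compounds go, is whether the trend continues with an ethyl or a longer chain on the amide nitrogen, with a second methyl on that nitrogen, or with a carboxylic acid at the same carbon, and compound 2 cannot settle this since it differs from these compounds in more than one place. Nothing on hand accounts for the size of these steps.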